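A few compounds are considered here, and "the series" means these few. Any claim that something is new, unique, unknown or untested is made for them only; others in the source may bear on it.

Measured compounds:
- Compound 1 `CCOC(=O)C1=C(S[C@@H]2CN[C@H](C(=O)Nc3cccc(C(=O)O)c3)C2)[C@H](C)[C@@H]2[C@@H]([C@@H](C)O)C(=O)N12` in a physicochemical assay for metabolic stability, read by LC-MS, in phosphate buffer, with a stated time of 3 h, at pH 7.4, tested at 50 uM (a lower number here means that less of the compound is left, a higher number that more of the compound is left), gives > 95%, a limit of the assay rather than a number.
- Compound 2 `CCOC(=O)C1=C(S[C@@H]2CN[C@H](C(=O)Nc3cccc(C(=O)OCC)c3)C2)[C@H](C)[C@@H]2[C@@H]([C@@H](C)O)C(=O)N12` gives > 95%, also a limit.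
- Compound 3 `CC(=O)OCOC(=O)C1=C(S[C@@H]2CN[C@H](C(=O)Nc3cccc(C(=O)OCOC(C)=O)c3)C2)[C@H](C)[C@@H]2[C@@H]([C@@H](C)O)C(=O)N12` gives > 95%, again a limit.

Compound 1 therefore stands at the upper limit of this assay, and the same is true of compound 2 and compound 3, so that the limit of > 95% in this assay, at which 3 of the 3 values shown sit, is all the evidence there is. Going by the values given here, the only single-point step between measured compounds, a step that the two limits leave unreadable from compound 1 to compound 2, is left unreadable by the two limits; the step from compound 1 to compound 3 is not a single-point change, and its two values only show that both compounds sit at the limit.

Compound 4 `C[C@@H](O)[C@H]1C(=O)N2C(C(=O)OCOC(=O)OC(C)(C)C)=C(S[C@@H]3CN[C@H](C(=O)Nc4cccc(C(=O)O)c4)C3)[C@H](C)[C@H]12` differs from compound 1 by (tert-butoxycarbonyl)oxy in place of methyl on a saturated chain carbon bound to an oxygen next to a carbonyl group. Among the compounds with values here, no measured step bears directly on this change. The ester variations seen in compound 2 and compound 3 each kept the compound at the limit, and nothing here suggests that compound 4 should behave differently. Compound 4 is therefore expected to show a step of a number no higher from compound 1 to compound 4 (the limit leaves the size open), that is, no step beyond the scatter. The estimate for compound 4 in this assay is 95%, with a range from 85% to 99%.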

Compound 4, percent of the compound remaining: > 95%
Compound 4: a limit, no number; the forecaster's own chance of this, stated with the estimate: 80%; the middle value sits exactly at the limit.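

In this assay compound 4 gives > 95%, a limit of the assay and not a number. No step can be read from compound 1 to compound 4, since both sit at the same limit: the limit of > 95% in this assay, at which 4 of the 4 values shown sit.

The compounds shown leave open whether any change at the ester groups moves the percent of compound remaining in this assay at all.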